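The source may report more compounds than this note shows. Statements on the series, on what has been measured and on what is new or still open speak of the compounds shown alone.

Measured in an ADME assay on HepG2 cells (Homo sapiens) for cytotoxicity, read by neutral red uptake, with a stated time of 24 h; a lower number here means a stronger inhibitor, a higher number a weaker inhibitor:
Compound 1 `CCCC(=O)Oc1c(C(C)C)cc2c3c1OC(=O)[C@@]31CCCC(C)(C)[C@@H]1CC2`: 56100 nM
Compound 2 `CCCCCCCCCCCC(=O)Oc1c(C(C)C)cc2c3c1OC(=O)[C@@]31CCCC(C)(C)[C@@H]1CC2`: > 1000000 nM

The entry for compound 2, > 1000000 nM, is a limit of the assay and not a number. The next structure is compound 3 `CC(C)c1cc2c3c(c1OC(=O)c1ccccc1)OC(=O)[C@@]31CCCC(C)(C)[C@@H]1CC2`, and the change is phenyl in place of undecyl on a carbonyl carbon. Among the compounds with values here, only one measured step bears on this, an at least 17-fold higher number from compound 1 to compound 2 (1.25 log units; beyond the scatter), a large step beyond the scatter that lengthens the chain on that same carbonyl. As far as these compounds go, compound 3 gives up the undecyl chain, so a large move back towards compound 1 at 56100 nM is expected, though phenyl itself is untested. The expected change is an at least 10-fold lower number from compound 2 to compound 3 (1.00 log units; beyond the scatter), towards a lower number. For compound 3 the estimated value in this assay is 100000 nM, with an expected range of 30000 nM to 400000 nM.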

Compound 3, half-maximal inhibitory concentration: 510000 nM
The estimate for compound 3 lay 5.1-fold (0.71 log units) below the measured number, outside the stated range (above it).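

Phenyl in place of propyl on this carbonyl carbon gives a 9.1-fold higher number from compound 1 to compound 3 (0.96 log units; beyond the scatter) in this assay, so the number rises from compound 1 with a ring there as well as with the long undecyl chain. Phenyl in place of undecyl gives only an at least 1.9-fold lower number from compound 2 to compound 3 (0.29 log units; that floor lies within the scatter), which sets no order between these two compounds. The entry for compound 2 is a limit of the assay and not a number: the limit of > 1000000 nM in this assay, at which 1 of the 3 values shown sits.

Open, as far as these compounds go, is whether a shorter acyl group such as acetyl, or a free hydroxyl in place of the ester, would bring the number under that of compound 1. Also open, from the compounds shown here alone, is how a chain of intermediate length, or a phenyl ring carrying an amine or a carboxylic acid, would compare with compound 3.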